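The compounds below may be only part of what the source reports. "The series", "measured", "known", "first", "only" and "open" are said of these compounds alone.

In a functional assay on Hep cells (Homo sapiens) for cytotoxicity, read by sulforhodamine B assay, with a stated time of 48 h (a higher number here means a weaker inhibitor, a lower number a stronger inhibitor), compound 1 `CC1=C(/C=C/C(=O)/C=C/c2ccc(Br)cc2)C(C)(C)CCC1` gives 34500 nM, the lowest of the two numbers at hand. For the measured compounds named here, its one companion, compound 2 `CC1=C(/C=C/C(=O)/C=C/c2ccc(F)cc2)C(C)(C)CCC1`, gives 55800 nM in this assay, and the single measured step, a 1.6-fold higher number from compound 1 to compound 2 (0.21 log units; within the scatter), came from fluoro replacing bromo and stayed within the scatter of the method. The compound not yet measured is compound 3 `CC1=C(/C=C/C(=O)/C=C/c2ccc(C#N)cc2)C(C)(C)CCC1`, which differs from compound 1 in one place: cyano in place of bromo on an aromatic carbon. Going by the values given here, no measured step exchanges bromo for cyano, so the only guidance is the step from compound 1 to compound 2, where exchanging one group at that same aromatic carbon for another left the number within the scatter. On that basis no step beyond the scatter is expected in this assay for compound 3, and its number is estimated close to that of compound 1, the expected step from compound 1 to compound 3 being a 1.2-fold higher number from compound 1 to compound 3 (0.06 log units; within the scatter). Among the compounds with values here, the estimate for compound 3 in this assay is therefore 40000 nM, with a range from 15000 nM to 110000 nM that is wide because only one nearby step is known.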

Compound 3, half-maximal inhibitory concentration: 45600 nM
Estimate against measurement, compound 3: 1.1-fold (0.06 log units) below, within the range that was stated.
By their numbers in this assay, from the lowest: compounds 1, 3 and 2 (each within the scatter of the next).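

In this assay, the exchange of bromo for cyano gives a 1.3-fold higher number from compound 1 to compound 3 (0.12 log units; within the scatter) and the exchange of fluoro for cyano gives a 1.2-fold lower number from compound 2 to compound 3 (0.09 log units; within the scatter), so all three groups at this place, on an aromatic carbon para to a large group, now stand within the scatter of one another. The earlier pair compared only two halogens, whereas cyano brings two heavy atoms, a triple bond and one hydrogen-bond acceptor where bromo had one heavy atom and no acceptor, and this change in the group still produces no step beyond the scatter. Nothing on hand explains why the number stays so flat across these three groups.

Whether any group at this place can move the number beyond the scatter remains open, as the compounds shown carry only bromo, fluoro and cyano there and say nothing about an amine, a carboxylic acid or a longer chain such as a butyl group. As far as these compounds go, all three compounds also share the core of compound 1, so the effect of changes elsewhere on that core is unknown.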